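Allyloxy to benzyloxy on a shared core: cytotoxicity outlook

This account rests on a few compounds, and the source may have more. Where it says the series, first, only, none or still open, it means among the compounds named here.

Compound 3 `C=CCONC(=O)CN1C(=O)S/C(=C\c2cccc(C(=O)N[C@@H](CC(C)C)C(=O)OC)c2)C1=O` belongs to a small set of compounds built on one shared core. In a functional assay on MRC5 cells (Homo sapiens) for inhibition, read by microscopy and resazurin assay, with a stated time of 72 h (on this read-out higher numbers stand for weaker inhibition and lower numbers for stronger inhibition), compound 3 gives > 128000 nM, which is a limit of the assay and not a number. Compound 1 `C=CCONC(=O)CN1C(=O)S/C(=C\c2ccc(C(=O)N[C@@H](CC(C)C)C(=O)OC)cc2)C1=O` differs from compound 3 only elsewhere in the core. In this assay compound 1 gives > 128000 nM, again a limit rather than a number. Compound 2 `COC(=O)[C@H](CC(C)C)NC(=O)c1ccc(/C=C2\SC(=O)N(CC(=O)NOCc3ccccc3)C2=O)cc1` gives > 128000 nM in this assay, once more a limit. The step that the two limits leave unreadable from compound 1 to compound 2 is therefore not readable, since (the limit of > 128000 nM in this assay, at which 3 of the 3 values shown sit).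

Compound 4 `COC(=O)[C@H](CC(C)C)NC(=O)c1cccc(/C=C2\SC(=O)N(CC(=O)NOCc3ccccc3)C2=O)c1` stands to compound 3 as compound 2 stands to compound 1: phenyl in place of vinyl on a saturated chain carbon bound to an oxygen on an unsaturated carbon. Going by the values given here, the only measured step of this kind is the one just named, and both of its ends rest at the limit, so no size or direction can be taken from it. Compound 4 is expected to show no step beyond the scatter, a step that the limit leaves unreadable from compound 3 to compound 4, and will most likely again be reported as a limit. Compound 4 is estimated at 200000 nM, within 100000 nM to 500000 nM.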

Compound 4, half-maximal inhibitory concentration: > 128000 nM
Compound 4 ended at the assay's limit; the forecaster's own chance of this, stated with the estimate: 90%; the middle value lies beyond the limit too.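

No new step can be read from compound 3 to compound 4, since neither gives a number, only a limit of the assay: the limit of > 128000 nM in this assay, at which 4 of the 4 values shown sit.

The compounds shown leave open how strongly any of them inhibits in this assay, and whether allyloxy or benzyloxy makes any difference there.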